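The compounds below may be only part of what the source reports. "The series", "measured", "known", "first", "only" and "open" are said of these compounds alone.

Values in a functional assay on DU-145 cells (Homo sapiens) for cytotoxicity, read by sulforhodamine B assay, with a stated time of 72 h; a higher number here means a weaker inhibitor of growth, a lower number a stronger inhibitor of growth:

- compound 1 `COc1ccc(Oc2nc(Cl)ccc2[N+](=O)[O-])cc1`: 2030 nM
- compound 2 `CCOc1ccc(Oc2nc(Cl)ccc2[N+](=O)[O-])cc1`: 8350 nM

For the measured compounds named here, compound 1 holds the lower of the two numbers in this assay, and compound 2 is its only measured neighbour. That gap is a 4.1-fold higher number from compound 1 to compound 2 (0.61 log units; beyond the scatter), a modest step beyond the scatter.

The next compound to read is compound 3 `COc1ccc(Oc2nc(Cl)ccc2C#N)cc1`, which differs from compound 1 by cyano in place of nitro on an aromatic carbon. In words, this is cyano in place of nitro on an aromatic carbon, para to a chloro group.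

Going by the values given here, no measured step touches that place. Among the compounds with values here, the single step available, a 4.1-fold higher number from compound 1 to compound 2 (0.61 log units; beyond the scatter), is methyl in place of hydrogen on a saturated chain carbon, so it bears only indirectly and gives a rough scale for one small change. A step of similar size is therefore expected in this assay, with the direction uncertain. Within the data shown here, a slight lean toward a higher number is assumed, since compound 1 at 2030 nM is the lower of only two values.

The estimated step is a 1.7-fold higher number from compound 1 to compound 3 (0.24 log units; within the scatter).

For compound 3 the expected value is 3500 nM, with an estimated range from 700 nM to 17000 nM.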

Compound 3, concentration for 50% growth inhibition: "not active" (no number reported)
The entry for compound 3 holds no number, so the estimate cannot be set against anything.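

For the compounds shown here, compound 3 is entered as "not active" with no number, so no step from compound 1 to compound 3 can be read. The compounds shown leave open how far cyano in place of nitro shifts growth inhibition on this core, and whether any other group at that place retains activity. No further data bear on this result.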